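The source may report more compounds than this note shows. Statements on the series, on what has been measured and on what is new or still open speak of the compounds shown alone.

Measured compounds, with values from an assay for inhibition of high affinity nerve growth factor receptor (Homo sapiens), read by HTRF, with a stated time of 30 min, in the presence of a further agent that is not named here; on this read-out higher numbers stand for weaker inhibition and lower numbers for stronger inhibition:
compound 1, `Cc1cc(Nc2nc(NCc3ccc(Br)cc3)nc3ccccc23)n[nH]1`, gives 180 nM
compound 2, `Cc1ccc(CNc2nc(Nc3cc(C)[nH]n3)c3ccccc3n2)cc1`, gives 110 nM
compound 3, `Cc1cc(Nc2nc(NCc3ccc(F)cc3F)nc3cc(Br)ccc23)n[nH]1`, gives 53 nM

Compound 1 and compound 2 differ by methyl in place of bromo on an aromatic carbon, and the step in this assay is a 1.6-fold lower number from compound 1 to compound 2 (0.21 log units; within the scatter). Compound 3 stands lowest of the three, and its difference from compound 1 lies in the cores, which is not broken down here.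

Compound 4, `Cc1ccc2c(Nc3cc(C)[nH]n3)nc(NCc3ccc(F)cc3F)nc2c1`, is not yet measured. From compound 3 it differs by methyl in place of bromo on an aromatic carbon, the same kind of change as from compound 1 to compound 2, though not the same: there the place was on a six-membered aromatic ring of carbon only, para to a large group; here it is on a ring that is part of a fused or bridged system of two rings, meta to a fused ring and para to a fused ring. Because the earlier step was a 1.6-fold lower number from compound 1 to compound 2 (0.21 log units; within the scatter), a step of about a 1.3-fold lower number from compound 3 to compound 4 (0.12 log units; within the scatter) is expected for compound 4 in this assay. The estimate for compound 4 is 40 nM.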

Compound 4, half-maximal inhibitory concentration: 27 nM
Compound 4: middle estimate off by 1.5-fold (0.17 log units), on the high side; low and high end bracket the measured number.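

In this assay, methyl in place of bromo on an aromatic carbon gives a 2.0-fold lower number from compound 3 to compound 4 (0.29 log units; within the scatter). Set beside the earlier step on the other core, the change carries over with no difference in size that can be told apart: the same change on two cores in this assay, a 1.6-fold lower number (0.21 log units; within the scatter) from compound 1 to compound 2 and a 2.0-fold lower number (0.29 log units; within the scatter) from compound 3 to compound 4, 1.2-fold (0.08 log units) apart, within the scatter of two such steps. Among the compounds shown here, these are only two pairs, with the change at a different place in each and each step within the scatter on its own, so they show that the swap is tolerated on both cores, not that methyl improves on bromo or that the result extends to any further core.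

Open, as far as these compounds go, is whether other groups at the same place, such as a nitrile, an amine or a carboxylic acid, would shift the number beyond the scatter. Also open, from the compounds shown here alone, is how the swap reads outside this assay.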